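Isopropyl to cyclopropyl on two related sulfonylurea-type cores

The source may hold more compounds than are shown below. What is called first, only, known or untested is meant among the compounds shown, and "the series" means these compounds.

Measured compounds:
compound 1 `CC(C)NC1=NS(=O)(=O)c2ccc(Cl)cc2N1`, 53400 nM in a functional assay on aorta (Rattus norvegicus) for inhibition; on this read-out higher numbers stand for an effect only at larger amounts of compound and lower numbers for an effect already at smaller amounts
compound 2 `O=S1(=O)N=C(NC2CC2)Nc2cc(Cl)ccc21`, 156000 nM in this assay
compound 3 `CC(C)NC1=NS(=O)(=O)c2cc(Cl)ccc2N1`, 36300 nM in this assay

Compound 1 and compound 3 have the same atoms joined differently; the difference between the two cores is not broken down here. Compound 2 and compound 1 are related by cyclopropyl in place of isopropyl on an amine nitrogen, and this change gives a 2.9-fold higher number from compound 1 to compound 2 (0.47 log units; beyond the scatter) in this assay. Compound 3 sits within the scatter of compound 1 in this assay, so no order between those two is claimed, while compound 2 stands apart from both.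

Compound 4 `O=S1(=O)N=C(NC2CC2)Nc2ccc(Cl)cc21` is not yet measured. It differs from compound 3 by cyclopropyl in place of isopropyl on an amine nitrogen, the same change as seen between compound 1 and compound 2, at the same place. A step of similar size, a 2.9-fold higher number from compound 3 to compound 4 (0.46 log units; beyond the scatter), is expected for compound 4 in this assay, because compound 1 to compound 2 gave a 2.9-fold higher number from compound 1 to compound 2 (0.47 log units; beyond the scatter) and compound 3 starts from 36300 nM. Compound 4 is thus estimated at 105000 nM in this assay, with a likely range from 50000 nM to 220000 nM. This rests on a single prior instance of the change.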

Compound 4, half-maximal effective concentration: 191000 nM
Estimate against measurement, compound 4: 1.8-fold (0.26 log units) below, within the range that was stated.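

In this assay the exchange of isopropyl for cyclopropyl on an amine nitrogen moves the number the same way on the second core as on the first (a 5.3-fold higher number from compound 3 to compound 4 (0.72 log units; beyond the scatter)). Set side by side, the two steps do not separate in size: the same change on two cores in this assay, a 2.9-fold higher number (0.47 log units; beyond the scatter) from compound 1 to compound 2 and a 5.3-fold higher number (0.72 log units; beyond the scatter) from compound 3 to compound 4, 1.8-fold (0.26 log units) apart, within the scatter of two such steps

Within these two matched pairs, the change therefore carries from one core to the other in direction and, given the scatter, in size, but two pairs cannot establish a general rule for the series, and the apparently larger second step should not be read as a real effect of the core.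

Still open, as far as these compounds go, is whether a cyclobutyl group, a straight propyl chain or an unsubstituted amine on the same nitrogen would give a step of similar size on both cores. Also open, from the compounds shown here alone, is whether the step would persist with a bromine or a nitrile in place of the chlorine.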